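Cytotoxicity of a quinolinone amine series: from compound 1 to compound 4

The source may report more compounds than this note shows. Statements on the series, on what has been measured and on what is new or still open speak of the compounds shown alone.

The compounds were compared in a toxicity assay on MDCK cells (Canis lupus familiaris) for cytotoxicity, read by crystal violet staining, with a stated time of 48 h; a higher number here means that more compound is tolerated, a lower number that less compound is tolerated. Compound 1 `CCc1ccc2[nH]c(=O)c(CN(Cc3ccc(F)cc3)Cc3ccc(C(C)(C)C)cc3)cc2c1` reaches only the limit of > 33000 nM in this assay, and that is a limit rather than a number. Compound 2 `CC(C)c1ccc2[nH]c(=O)c(CN(Cc3ccc(F)cc3)Cc3ccc(C(C)(C)C)cc3)cc2c1` gives 7900 nM, so the change an at least 4.1-fold lower number from compound 1 to compound 2 (0.62 log units; beyond the scatter). Compound 3 `CCc1ccc2[nH]c(=O)c(CN(Cc3ccc(F)cc3)Cc3cccc4ccccc34)cc2c1` gives > 5000 nM, which is again a limit. The step that the two limits leave unreadable from compound 1 to compound 3.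

Compound 4 `CCc1ccc2[nH]c(=O)c(CN(Cc3ccc(C(C)(C)C)cc3)C(C)c3ccc(OC)c(Cl)c3)cc2c1` differs from compound 1 in one place: 1-(3-chloro-4-methoxyphenyl)ethyl in place of 4-fluorobenzyl on an amine nitrogen. For the measured compounds named here, no measured step shares this change; the nearest is the step to compound 2, where a methyl added to a chain carbon gave an at least 4.1-fold lower number from compound 1 to compound 2 (0.62 log units; beyond the scatter). The entering group is larger and also carries a methyl on the chain carbon, so a lower number is expected for compound 4, by about an at least 2.2-fold lower number from compound 1 to compound 4 (0.34 log units; beyond the scatter). Compound 4 is therefore expected to give about 15000 nM in this assay, with a range from 4000 nM to 50000 nM.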

Compound 4, half-maximal cytotoxic concentration: > 10000 nM
Compound 4: only a limit was reported; the forecaster's own chance of this, stated with the estimate: 35%; the middle value lies beyond the limit too.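

In this assay compound 4 gives > 10000 nM, which is a limit. Compound 1 also stands at a limit, and the step between them cannot be read. Still open, from the compounds shown here alone, is whether 1-(3-chloro-4-methoxyphenyl)ethyl in place of 4-fluorobenzyl changes the tolerated concentration at all.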